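The source may hold more compounds than are shown below. What is called first, only, known or untested is meant among the compounds shown, and "the series" means these compounds.

Going by the values given here, in a functional assay on OVCAR-3 cells (Homo sapiens) for antiproliferative activity, read by sulforhodamine B assay, with a stated time of 72 h (a lower number here means a stronger inhibitor, a higher number a weaker inhibitor), compound 1 `NC(=S)NNc1nncc2ccccc12` gives 74 nM, the highest of the three numbers known, although its gaps to the other two are within the usual scatter. Compound 2 `Cc1cc(NS(=O)(=O)c2ccc(Nc3nncc4ccccc34)cc2)no1` gives 54 nM, and compound 3 `O=S(=O)(Nc1nccs1)c1ccc(Nc2nncc3ccccc23)cc1` gives 43 nM. Among the compounds with values here, the one step measured between neighbouring compounds, a 1.3-fold lower number from compound 2 to compound 3 (0.10 log units; within the scatter), exchanges one ring for another on a sulfonamide nitrogen and did not move the number beyond the scatter.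

Compound 4 `S=C(NNc1nncc2ccccc12)Nc1ccccc1` is compound 1 with phenyl in place of hydrogen on an amide-type nitrogen. Within the data shown here, no measured step touches this amide-type nitrogen, so there is nothing that directly shows what the change does. Among the measured compounds shown here, the only guidance is that the single known change elsewhere, as measured, left the number where it was, and that all three measured compounds sit close together. On that basis a step of no more than the scatter is expected, a 1.2-fold lower number from compound 1 to compound 4 (0.09 log units; within the scatter), in no particular direction. Compound 4 is therefore estimated at 60 nM, with a range from 20 nM to 200 nM in this assay.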

Compound 4, half-maximal inhibitory concentration: 6 nM
The estimate for compound 4 lay 10-fold (1.00 log units) above the measured number; measured number outside the range, below it.
By their numbers in this assay, from the lowest: compound 4; then compounds 3, 2 and 1 (each within the scatter of the next).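

In this assay, the amide-type nitrogen of compound 1 proves to be a place where the number responds strongly: phenyl in place of hydrogen gives a 12-fold lower number from compound 1 to compound 4 (1.09 log units; beyond the scatter), so a single hydrogen can give way to an aromatic ring of six carbons with a large gain. Going by these compounds alone, the only earlier step, a 1.3-fold lower number from compound 2 to compound 3 (0.10 log units; within the scatter), exchanged one ring for another on a sulfonamide nitrogen and gave no hint of a change of this size. Nothing measured here accounts for the drop.

Phenyl is the only group shown on this nitrogen, so it remains open whether a methyl, a benzyl or a cyclohexyl group would do the same. Going by these compounds, it is equally open whether a chlorine or a methoxy group on the phenyl ring would lower the number further or raise it.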